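Isopropyl on a Shorter Chain: Expectation for Compound 4

The source may hold more compounds than are shown below. What is called first, only, known or untested is meant among the compounds shown, and "the series" means these compounds.

Compound 1 `O=C(O)c1cc(CCCNS(=O)(=O)c2ccccc2)c2cccccc1-2` sits at the top of the measured series: in a functional assay (thoracic aorta) for inhibition, with Rattus norvegicus as the target (on this read-out lower numbers stand for stronger inhibition and higher numbers for weaker inhibition), compound 1 gives 4800 nM. Compound 2 `O=C(O)c1cc(CCCCCNS(=O)(=O)c2ccccc2)c2cccccc1-2` differs from compound 1 by more than one feature, and the difference between the two cores is not broken down here; in this assay compound 2 gives 840 nM. Compound 3 `CC(C)c1ccc2c(CCCCCNS(=O)(=O)c3ccccc3)cc(C(=O)O)c-2cc1` carries the change isopropyl in place of hydrogen on an aromatic carbon relative to compound 2, and in this assay compound 3 gives 120 nM, a step of a 7.0-fold lower number from compound 2 to compound 3 (0.85 log units; beyond the scatter).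

Compound 4 `CC(C)c1cccc2c(CCCNS(=O)(=O)c3ccccc3)cc(C(=O)O)c-2c1` has not yet been measured. It relates to compound 1 through (isopropyl in place of hydrogen on an aromatic carbon), the same change as that from compound 2 to compound 3, at the same kind of place. The step from compound 1 to compound 4 is expected to be of similar size, a 6.0-fold lower number from compound 1 to compound 4 (0.78 log units; beyond the scatter), because compound 3 improved on compound 2 by a 7.0-fold lower number from compound 2 to compound 3 (0.85 log units; beyond the scatter). Compound 4 is therefore estimated at 800 nM in this assay, with a plausible range from 300 nM to 2500 nM, since this rests on a single earlier occurrence of the change.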

Compound 4, half-maximal inhibitory concentration: 7400 nM
Beside the measured number, compound 4's estimate is 9.3-fold (0.97 log units) below it; measured number above the stated range.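

In this assay, isopropyl in place of hydrogen on an aromatic carbon of the core of compound 1 gives a 1.5-fold higher number from compound 1 to compound 4 (0.19 log units; within the scatter), a result that cannot be told apart from no change at all. The gain seen earlier therefore does not carry over to this core, and the two occurrences of the change disagree: the same change on two cores in this assay, a 7.0-fold lower number (0.85 log units; beyond the scatter) from compound 2 to compound 3 and a 1.5-fold higher number (0.19 log units; within the scatter) from compound 1 to compound 4, 11-fold (1.03 log units) apart, beyond the scatter of two such steps. This shows that, across these two pairs, the size of the step cannot be read from one core and applied to the other; it does not show which difference between the cores is responsible, nor how the change would behave on any further core.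

Going by these compounds, it remains open whether a smaller group such as methyl, or a chlorine atom, in place of isopropyl would also differ between the two cores. On these data alone, it also remains open whether isopropyl would give a gain on a core with a chain of intermediate length, or with an amide in place of the sulfonamide.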